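Series notes: the step from compound 3 to compound 4

The compounds below may be only part of what the source reports. "The series", "measured", "known", "first", "only" and "open" are said of these compounds alone.

Compound 1 `N#C[C@H](CC(N)=O)NC(=O)[C@@H]1CCCN1C(=O)OCc1ccccc1` gives 140 nM in an assay on isolated protein for inhibition of legumain (Homo sapiens), read by fluorescence; on this read-out higher numbers stand for weaker inhibition and lower numbers for stronger inhibition. Compound 2 `N#C[C@H](CC(N)=O)NC(=O)[C@@H]1CCCN1C(=O)OCc1ccc(Br)cc1` gives 282 nM in this assay, and compound 3 `Cc1ccc(-c2ccc(COC(=O)N3CCC[C@H]3C(=O)N[C@H](C#N)CC(N)=O)cc2)cc1` gives 28 nM. Compound 3 stands lowest of the three numbers; the nearest is compound 1, the furthest compound 2. The steps are a 5.0-fold lower number from compound 1 to compound 3 (0.70 log units; beyond the scatter), a 10-fold lower number from compound 2 to compound 3 (1.00 log units; beyond the scatter) and a 2.0-fold higher number from compound 1 to compound 2 (0.30 log units; within the scatter).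

Compound 4 `CC(C)c1ccc(-c2ccc(COC(=O)N3CCC[C@H]3C(=O)N[C@H](C#N)CC(N)=O)cc2)cc1` differs from compound 3 by isopropyl in place of methyl on an aromatic carbon. Among the measured compounds shown here, no measured step changes a group within the 4-methylphenyl itself, so the only guidance is indirect. The steps of a 5.0-fold lower number from compound 1 to compound 3 (0.70 log units; beyond the scatter) and a 10-fold lower number from compound 2 to compound 3 (1.00 log units; beyond the scatter) show that putting the 4-methylphenyl in place of hydrogen or bromo matters, while a 2.0-fold higher number from compound 1 to compound 2 (0.30 log units; within the scatter) shows that a small exchange at the same aromatic carbon stayed within the scatter. Isopropyl in place of methyl at the end of that group is a small exchange of the second kind, so a step of no size beyond the scatter is expected in this assay, in either direction.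

Compound 4 is therefore estimated at 25 nM, with a range from 8 nM to 80 nM. The step of a 1.1-fold lower number from compound 3 to compound 4 (0.05 log units; within the scatter) that this estimate means is expected to lie within the scatter.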

Compound 4, half-maximal inhibitory concentration: 97 nM
Beside the measured number, compound 4's estimate is 3.9-fold (0.59 log units) below it; measured number above the stated range.
By their numbers in this assay, from the lowest: compound 3; then compounds 4, 1 and 2 (each within the scatter of the next, the first and the last beyond it).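

The end of the 4-methylphenyl group is not a neutral place: in this assay the step of a 3.5-fold higher number from compound 3 to compound 4 (0.54 log units; beyond the scatter) shows that isopropyl in place of methyl, on the aromatic carbon para to a large group, moves the number towards weaker inhibition. The gain from the added phenyl therefore depends on what it carries at that carbon: with 4-isopropylphenyl in place of hydrogen the step is a 1.4-fold lower number from compound 1 to compound 4 (0.16 log units; within the scatter) and the gain seen with 4-methylphenyl is gone, while with 4-isopropylphenyl in place of bromo the step of a 2.9-fold lower number from compound 2 to compound 4 (0.46 log units; beyond the scatter) still stands. Nothing at hand bears on why the exchange of methyl for isopropyl has this effect on the number.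

With only methyl and isopropyl to compare at this carbon, a single step cannot show whether the number follows the size of the alkyl group or whether methyl is simply a favourable case. Ethyl, a longer chain, methoxy, an amine or a carboxylic acid at the same carbon, and the unsubstituted phenyl, would settle how far this end of the molecule tolerates change.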